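The source may report more compounds than this note shows. Statements on the series, on what has been measured and on what is new or still open speak of the compounds shown alone.

Working notes, clearance series. The read-out throughout is an ADME assay on microsomes from liver (Homo sapiens) for metabolic stability, using NADPH, with a stated time of 60 min; on this read-out lower numbers stand for slow clearance and higher numbers for fast clearance.

Compound 1 `CC(C)(NC(=O)Nc1ccc(F)c(C(F)(F)F)c1)C(=O)O` — compound 1 gives < 7 uL/min, which is a limit of the assay and not a number.
Compound 2 `CC(C)(NC(=O)Nc1ccccc1)C(=O)O` — compound 2 gives < 7 uL/min, again a limit rather than a number.
Compound 3 `CC(C)(C(=O)O)N1CCCN(c2ccc(F)c(C(F)(F)F)c2)C1=O` — compound 3 gives < 7 uL/min, also a limit.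

Where compound 1 stands, then, is at the floor of this assay, and the two other results are limits as well; all three rest on (the limit of < 7 uL/min in this assay, at which 3 of the 3 values shown sit). No pair among these three differs in a single place, so no measured step is available and no order among them can be stated.

Compound 4 `CC(C)(CC(=O)Nc1ccc(F)c(C(F)(F)F)c1)C(=O)O` is not yet measured. Relative to compound 1 it carries 2-carboxy-2-methylpropyl in place of (1-carboxy-1-methylethyl)amino on a carbonyl carbon. The carboxylic acid and the gem-dimethyl pair are retained within the 2-carboxy-2-methylpropyl group, while the nitrogen of the (1-carboxy-1-methylethyl)amino group is gone. Because every measured member sits on (the limit of < 7 uL/min in this assay, at which 3 of the 3 values shown sit), the working expectation is a step of none beyond the scatter, with the result most likely returned once more as a limit. For compound 4 the estimate in this assay is 7 uL/min, in the range 3 uL/min to 18 uL/min. The step this estimate means is expected to be a number no lower from compound 1 to compound 4 (the limit leaves the size open).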

Compound 4, intrinsic clearance in a liver preparation (reported as CLH), per the amount of preparation that the assay uses: < 7 uL/min
Compound 4 ended at the assay's limit (the forecaster's own chance of this, stated with the estimate: 60%); the middle value lies on the limit itself.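

Within the data shown here, no step from compound 1 to compound 4 can be read in this assay, since both results are limits of the assay and not numbers: the limit of < 7 uL/min in this assay, at which 4 of the 4 values shown sit.
The compounds shown leave open how the four stand relative to one another in this assay and whether 2-carboxy-2-methylpropyl in place of (1-carboxy-1-methylethyl)amino on a carbonyl carbon alters clearance at all.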